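Adding a Methyl to the Aromatic Ring of Compound 1

A few compounds are considered here, and "the series" means these few. Any claim that something is new, unique, unknown or untested is made for them only; others in the source may bear on it.

Among the measured compounds shown here, compound 1, `CC1CCCN1C1CCN(c2ccc(NC(=O)C3CCCO3)cc2)C1`, sits at the favourable end of the two numbers measured so far. In an assay on CHO cells for displacement of a labelled ligand from histamine receptor H3 (Macaca mulatta) (a higher number here means a weaker inhibitor, a lower number a stronger inhibitor), compound 1 gives 8.7 nM. Its only neighbour is compound 2, `CC(=O)N1CCCC1C(=O)Nc1ccc(N2CCC(N3CCCC3C)C2)cc1`, which in this assay gives 14.1 nM; the step of a 1.6-fold higher number from compound 1 to compound 2 (0.21 log units; within the scatter) lies within the scatter, so these two compounds cannot be told apart on the numbers shown. Compound 3, `Cc1cc(NC(=O)C2CCCO2)ccc1N1CCC(N2CCCC2C)C1`, has not yet been measured. It differs from compound 1 by methyl in place of hydrogen on an aromatic carbon. For the measured compounds named here, no measured step speaks to a change of this kind: the one step known, a 1.6-fold higher number from compound 1 to compound 2 (0.21 log units; within the scatter), alters the group on the carbonyl carbon and leaves the aromatic ring untouched. With no direction to lean on, the expected step is a 1.0-fold higher number from compound 1 to compound 3 (0.01 log units; within the scatter), nothing beyond the scatter. Compound 3 is therefore estimated at 9 nM, within a range from 4 nM to 22 nM.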

Compound 3, inhibition constant: 17 nM
Beside the measured number, compound 3's estimate is 1.9-fold (0.28 log units) below it; the range from low to high includes it.
By their numbers in this assay, from the lowest: compounds 1, 2 and 3 (each within the scatter of the next).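

Among the compounds shown here, this is the first reading for a substituent on the aromatic ring rather than on the carbonyl carbon. In this assay, methyl in place of hydrogen on the ring carbon ortho to a large group gives a 2.0-fold higher number from compound 1 to compound 3 (0.29 log units; within the scatter) and so leaves the two compounds indistinguishable on these numbers. A single added carbon at this place therefore has no effect that can be separated from ordinary assay variation, and nothing shown offers an explanation for the reading.

From the compounds shown here alone, whether this position would accept something bigger or of a different kind, such as an ethyl group, a methoxy group or an amine, remains open. The compounds shown also leave open how a methyl would read on the other carbons of the ring.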